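The source may report more compounds than this note shows. Statements on the series, on what has been measured and on what is new or still open speak of the compounds shown alone.

Working notes on the series, read in a functional assay on PA-1 cells (Homo sapiens) for cytotoxicity, read by MTT assay, with a stated time of 4 h; a higher number here means a weaker inhibitor, a lower number a stronger inhibitor. Compound 1 `COC(=O)C1=CO[C@@H](O[C@@H]2O[C@H](CO)[C@@H](OC(C)=O)[C@H](OC(C)=O)[C@H]2OC(C)=O)[C@@H]2[C@@H](C)[C@@H](OC(C)=O)C[C@H]12` is recorded as "not active" (no number reported), with no number reported. Compound 2 `CCCCCCCCCCCC(=O)OC[C@H]1O[C@@H](O[C@@H]2OC=C(C(=O)OC)[C@H]3C[C@H](OC(C)=O)[C@H](C)[C@@H]23)[C@H](OC(C)=O)[C@@H](OC(C)=O)[C@@H]1OC(C)=O` gives 0.15 ug/mL. Among the compounds with values here, this is the only number so far, so compound 2 can be set only against that one non-numeric entry and cannot yet be ranked on a scale.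

Compound 3 `C=CC(=O)OC[C@H]1O[C@@H](O[C@@H]2OC=C(C(=O)OC)[C@H]3C[C@H](OC(C)=O)[C@H](C)[C@@H]23)[C@H](OC(C)=O)[C@@H](OC(C)=O)[C@@H]1OC(C)=O` is still unmeasured. It keeps the rest of compound 2 and alters only the acyl group: vinyl in place of undecyl on a carbonyl carbon, (vinyl in place of undecyl on a carbonyl carbon).

Within the data shown here, no step between measured compounds is available to size this change, so the expectation is loose. A move toward weaker inhibition in this assay, beyond the usual scatter, is expected. The only basis is the contrast between compound 2, which carries the undecyl ester at 0.15 ug/mL, and compound 1, which has no such ester and is recorded as "not active" (no number reported).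

The estimated shift is a 5.3-fold higher number from compound 2 to compound 3 (0.73 log units; beyond the scatter). For compound 3 the expected value is 0.8 ug/mL, with an estimated range of 0.15 ug/mL to 5 ug/mL.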

Compound 3, half-maximal inhibitory concentration: "not active" (no number reported)
For compound 3 the study gives words and no number, so the estimate cannot be set against anything.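

Within the data shown here, compound 3 is recorded in this assay in words only, so no step from compound 2 to compound 3 can be read. The compounds shown leave open how large the difference between the undecyl and vinyl groups is on a numerical scale. No measurement shown offers an explanation for this result.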